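Removing the methoxy from compound 1

The compounds below may be only part of what the source reports. "The series", "measured", "known", "first", "only" and "open" are said of these compounds alone.

Within the data shown here, compound 1 `COc1ccc(-c2[nH]c3ccccc3c2/C=C(\C#N)S(=O)(=O)c2ccccc2)cc1` is the weaker of the two measured members: in a functional assay on SK-MEL-28 cells (Homo sapiens) for inhibition, read by sulforhodamine B assay, with a stated time of 48 h (a higher number here means a weaker inhibitor of growth, a lower number a stronger inhibitor of growth), compound 1 gives 1800 nM, while compound 2 `COc1ccc(-c2[nH]c3ccc(OC)cc3c2/C=C(\C#N)S(=O)(=O)c2ccccc2)cc1` gives 787 nM. Among the measured compounds shown here, the one measured step, a 2.3-fold lower number from compound 1 to compound 2 (0.36 log units; beyond the scatter), comes from adding a methoxy on the shared core rather than from touching the 4-methoxyphenyl group. Compound 3 `N#C/C(=C\c1c(-c2ccccc2)[nH]c2ccccc12)S(=O)(=O)c1ccccc1` differs from compound 1 by hydrogen in place of methoxy on an aromatic carbon. For the measured compounds named here, no measured pair reports this change; the step from compound 1 to compound 2 only shows that a methoxy elsewhere helped, so it bears on the question indirectly. The expectation is that taking away the existing methoxy of compound 1 goes, if anywhere, the other way, with a small shift in this assay, a 1.4-fold higher number from compound 1 to compound 3 (0.16 log units; within the scatter), that may not exceed the scatter. Compound 3 is therefore estimated at 2600 nM, with a range from 900 nM to 7500 nM.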

Compound 3, concentration for 50% growth inhibition: 8300 nM
Beside the measured number, compound 3's estimate is 3.2-fold (0.50 log units) below it; measured number outside the range, above it.
By their numbers in this assay, from the lowest: compound 2; then compound 1; then compound 3.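

Among these compounds, the 4-methoxyphenyl to phenyl change gives the first measured step at this position, and in this assay it lies beyond the scatter (a 4.6-fold higher number from compound 1 to compound 3 (0.66 log units; beyond the scatter)). With the step on the shared core (a 2.3-fold lower number from compound 1 to compound 2 (0.36 log units; beyond the scatter)), both places measured so far show a lower number with methoxy than with hydrogen, and none of the compounds shown goes against this, though two places make a thin pattern. Nothing available explains why the methoxy matters at this position.

The compounds shown leave open whether the gain is specific to methoxy or would also appear with a hydroxy, an ethoxy, a chlorine or an amine at the same place. They also leave open whether the step from removing this methoxy holds on a core that carries the second methoxy.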